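Methoxy in Place of Methyl on Compound 3

This account rests on a few compounds, and the source may have more. Where it says the series, first, only, none or still open, it means among the compounds named here.

In a functional assay on HL-60 cells (Homo sapiens) for cytotoxicity, read by MTT assay, with a stated time of 72 h (on this read-out lower numbers stand for stronger inhibition and higher numbers for weaker inhibition), compound 1 (`COc1ccc(S(=O)(=O)c2nc3ccccc3nc2N2CCCC2)cc1`) gives 16000 nM and compound 2 (`COc1ccc(S(=O)(=O)c2nc3ccccc3nc2N2CCc3ccccc3C2)cc1`) gives 3690 nM. Compound 3 (`Cc1ccc(S(=O)(=O)c2nc3ccccc3nc2N2CCCC(O)C2)cc1`) gives 6080 nM, within the usual scatter of compound 2 and clearly lower than compound 1. Compound 4 (`COc1ccc(S(=O)(=O)c2nc3ccccc3nc2N2CCCC(O)C2)cc1`) carries methoxy in place of methyl on an aromatic carbon. For the measured compounds named here, the only measured step, a 4.3-fold lower number from compound 1 to compound 2 (0.64 log units; beyond the scatter), exchanges pyrrolidin-1-yl for 1,2,3,4-tetrahydroisoquinolin-2-yl and keeps methoxy throughout, so no measured pair tests this change. With no evidence for a shift in this assay, the expected result is no change beyond the scatter, namely a 1.0-fold lower number from compound 3 to compound 4 (0.01 log units; within the scatter). For compound 4 the estimated value is 6000 nM, with an expected range from 2500 nM to 14000 nM.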

Compound 4, half-maximal inhibitory concentration: 3050 nM
Estimate against measurement, compound 4: 2.0-fold (0.29 log units) above; low and high end bracket the measured number.
By their numbers in this assay, from the lowest: compounds 4, 2 and 3 (each within the scatter of the next); then compound 1.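

Methoxy in place of methyl, the change from 4-methylphenyl to 4-methoxyphenyl, gives a 2.0-fold lower number from compound 3 to compound 4 (0.30 log units; within the scatter) in this assay and so shows no shift clear of the usual scatter at this position. At the other varied position, 3-hydroxypiperidin-1-yl in place of 1,2,3,4-tetrahydroisoquinolin-2-yl gives a 1.2-fold lower number from compound 2 to compound 4 (0.08 log units; within the scatter) and stays within the scatter, whereas 3-hydroxypiperidin-1-yl in place of pyrrolidin-1-yl gives a 5.2-fold lower number from compound 1 to compound 4 (0.72 log units; beyond the scatter) and goes beyond it. Nothing available explains the cause of these steps.

From the compounds shown here alone, what an amine or a carboxylic acid would do in place of methoxy on this aromatic carbon remains open.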